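Methyl on the Amine: From Compound 2 to Compound 3

The source may report more compounds than this note shows. Statements on the series, on what has been measured and on what is new or still open speak of the compounds shown alone.

Compound 1 `NCc1nnc(Cc2ccccc2)s1`: 200 mg/kg
Compound 2 `NCc1nnc(-c2ccccc2-c2ccccc2)s1`: 22 mg/kg

In a functional assay on the whole organism with Mus musculus as the target (on this read-out lower numbers stand for an effect already at smaller amounts and higher numbers for an effect only at larger amounts of compound), compound 1 gives 200 mg/kg, while compound 2 gives 22 mg/kg, the lower of the two numbers, and this gap lies beyond the usual scatter. Compound 3 `CNCc1nnc(-c2ccccc2-c2ccccc2)s1` keeps the core of compound 2 and differs only by methyl in place of hydrogen on an amine nitrogen. For the measured compounds named here, no measured pair shows the effect of such a change here, so the expected step from compound 2 to compound 3 is small, within the scatter, in the direction a 1.1-fold higher number from compound 2 to compound 3 (0.06 log units; within the scatter). Compound 3 is therefore estimated at 25 mg/kg, with a range from 10 mg/kg to 60 mg/kg.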

Compound 3, dose for half-maximal effect: 20 mg/kg
Compound 3: middle estimate off by 1.3-fold (0.10 log units), on the high side, and the stated range covers the measured number.
By their numbers in this assay, from the lowest: compounds 3 and 2 (each within the scatter of the next); then compound 1.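

In this assay, methyl in place of hydrogen on an amine nitrogen gives a 1.1-fold lower number from compound 2 to compound 3 (0.04 log units; within the scatter) and so leaves the two compounds indistinguishable. This first measured pair at this position shows that this amine nitrogen can carry one methyl without a shift beyond the usual scatter. Nothing available explains this result. The compounds shown leave open whether a second methyl or a longer chain such as ethyl or propyl on this nitrogen would also stay within the scatter. They also leave open what an acetyl group there would do.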